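A few compounds are considered here, and "the series" means these few. Any claim that something is new, unique, unknown or untested is made for them only; others in the source may bear on it.

Measured in a toxicity assay on WI-38 cells (Homo sapiens) for cytotoxicity, read by MTT assay, with a stated time of 48 h; on this read-out higher numbers stand for weaker inhibition and lower numbers for stronger inhibition:
Compound 1 `Cn1cccc1C(=O)/C=C/c1ccc2c(c1)B(O)OC2` gives > 100000 nM, which is a limit of the assay rather than a number.
Compound 2 `O=C(/C=C/c1ccc2c(c1)B(O)OC2)c1ccc(F)cc1` gives 7600 nM.
Compound 3 `O=C(/C=C/c1ccc2c(c1)B(O)OC2)c1ccc(I)cc1` gives > 100000 nM, again a limit of the assay rather than a number.

Compound 3 thus stands at the limit of > 100000 nM in this assay, at which 2 of the 3 values shown sit; its strength in this assay is only bounded, not pinned down. Compound 4 `Cc1ccc(C(=O)/C=C/c2ccc3c(c2)B(O)OC3)cc1` has not yet been measured. It differs from compound 3 in one place: methyl in place of iodo on an aromatic carbon. Among the compounds with values here, two measured steps touch the neighbourhood of this change. Exchanging the group on the carbonyl carbon gave an at least 13-fold lower number from compound 1 to compound 2 (1.11 log units; beyond the scatter), and exchanging one halogen for another on the aromatic carbon gave an at least 13-fold higher number from compound 2 to compound 3 (1.11 log units; beyond the scatter); the remaining comparison, a step that the two limits leave unreadable from compound 1 to compound 3, cannot be sized. Only compound 2 yielded a readable number, while the two others sit at the limit. Within the data shown here, no measured step shows a methyl at this position, so the size of the move from iodo to methyl is open. Compound 4 is expected to show an at least 2.5-fold lower number from compound 3 to compound 4 (0.39 log units; beyond the scatter), with a real chance that the assay again reports only a limit. The estimate for compound 4 in this assay is 40000 nM, within a range from 8000 nM to 200000 nM.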

Compound 4, half-maximal inhibitory concentration: 22200 nM
Estimate against measurement, compound 4: 1.8-fold (0.26 log units) above, and the stated range covers the measured number.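

Within the data shown here, until now this position held only one readable number, so any change there could be sized only against a limit. Among these compounds, compound 4 supplies a second number, and in this assay methyl in place of fluoro on the aromatic carbon gives a 2.9-fold higher number from compound 2 to compound 4 (0.47 log units; beyond the scatter), the first step at this position with both ends measured. Methyl in place of iodo gives an at least 4.5-fold lower number from compound 3 to compound 4 (0.65 log units; beyond the scatter), and 4-methylphenyl in place of 1-methyl-1H-pyrrol-2-yl on the carbonyl carbon gives an at least 4.5-fold lower number from compound 1 to compound 4 (0.65 log units; beyond the scatter); both of these steps start from a limit of the assay, so each gives only a bound on the size. Exchanging one heavy atom at this carbon therefore separates compound 2, compound 4 and compound 3 into three distinct levels, with fluoro lowest, methyl in the middle and iodo at the limit, rather than a simple split between a readable number and a limit.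

How far iodo really lies above methyl stays unknown, as the top of the scale is cut off: the limit of > 100000 nM in this assay, at which 2 of the 4 values shown sit.
Also open, from the compounds shown here alone, is where a chloro, a methoxy, an amine or a carboxylic acid at this carbon would fall on this scale.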